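This account rests on a few compounds, and the source may have more. Where it says the series, first, only, none or still open, it means among the compounds named here.

Working notes on the series. Compound 1 `O=c1nc(-c2ccccc2)c2cc(-c3cccnc3)ccc2[nH]1` and compound 2 `O=c1nc(-c2ccccc2)c2cc(-c3cnc4ccccc4c3)ccc2[nH]1` share a core and differ in the aryl group attached to it. In an ADME assay on THP-1 cells (Homo sapiens) for cytotoxicity, read by MTT assay, with a stated time of 72 h (on this read-out lower numbers stand for an effect already at smaller amounts and higher numbers for an effect only at larger amounts of compound), compound 1 gives > 50000 nM, which is a limit of the assay and not a measured number. In this assay compound 2 likewise gives > 50000 nM, again only a limit. Compound 1 thus stands at the limit, and both values shown sit there (the limit of > 50000 nM in this assay, at which 2 of the 2 values shown sit). Among the compounds with values here, no step between measured compounds exists here, so nothing yet shows how the aryl group moves the read-out. Compound 3 `O=c1nc(-c2ccccc2)c2cc(-c3ccccc3)ccc2[nH]1` is not yet measured in this assay; it differs from compound 1 by phenyl in place of pyridin-3-yl on an aromatic carbon. Because both known values sit at the limit (the limit of > 50000 nM in this assay, at which 2 of the 2 values shown sit), no step beyond the scatter is expected, and the expected step in this assay is a step that the limit leaves unreadable from compound 1 to compound 3. For compound 3 the estimate in this assay is 60000 nM, with a range from 25000 nM to 200000 nM, and most likely it will again be reported only as a limit.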

Compound 3, half-maximal effective concentration: > 50000 nM
Compound 3 ended at the assay's limit; the forecaster's own chance of this, stated with the estimate: 85%; the middle value lies beyond the limit too.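

In this assay, within the data shown here, no step between compound 1 and compound 3 can be read, since both stand at a limit: the limit of > 50000 nM in this assay, at which 3 of the 3 values shown sit. The compounds shown leave open whether the aryl group on the shared core moves the read-out in this assay at all.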